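Hydroxy to hydrogen on the aryl ring of compound 3

The compounds below may be only part of what the source reports. "The series", "measured", "known", "first", "only" and "open" are said of these compounds alone.

Three compounds share one core and differ only in one aromatic substituent. Compound 1 `COc1cccc(C(=O)NCc2c(C)cc(C)[nH]c2=O)c1F` carries fluoro; in an assay on Sf9 cells for inhibition of histone-lysine N-methyltransferase EZH2 (Homo sapiens), read by scintillation counting, with a stated time of 60 min, in the presence of a further agent that is not named here (a lower number here means a stronger inhibitor, a higher number a weaker inhibitor), compound 1 gives only a limit, > 150000 nM. Compound 2 `COc1cccc(C(=O)NCc2c(C)cc(C)[nH]c2=O)c1Cl` carries chloro, and in this assay compound 2 gives 7200 nM. Compound 3 `COc1cccc(C(=O)NCc2c(C)cc(C)[nH]c2=O)c1O` carries hydroxy, and in this assay compound 3 gives 44000 nM, the higher of the two numbers, with a 6.1-fold higher number from compound 2 to compound 3 (0.79 log units; beyond the scatter). The remaining value, that of compound 1, is a limit. Compound 4 `COc1cccc(C(=O)NCc2c(C)cc(C)[nH]c2=O)c1` differs from compound 3 by hydrogen in place of hydroxy on an aromatic carbon. The measured steps of an at least 20-fold lower number from compound 1 to compound 2 (1.31 log units; beyond the scatter), an at least 3.4-fold lower number from compound 1 to compound 3 (0.53 log units; beyond the scatter) and a 6.1-fold higher number from compound 2 to compound 3 (0.79 log units; beyond the scatter) each swap one substituent at this carbon, but none removes the group entirely, so the direction for compound 4 in this assay is uncertain. Compound 4 is therefore estimated at 40000 nM, between 10000 nM and 150000 nM. That estimate implies a 1.1-fold lower number from compound 3 to compound 4 (0.04 log units; within the scatter), expected to stay within the scatter.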

Compound 4, half-maximal inhibitory concentration in the histone-lysine N-methyltransferase EZH2 assay: > 150000 nM
Compound 4 was reported as a limit (the forecaster's own chance of this, stated with the estimate: 25%); middle value at least 3.7-fold (0.57 log units) away from the limit.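

In the histone-lysine N-methyltransferase EZH2 assay compound 4 gives > 150000 nM, which is a limit. In the histone-lysine N-methyltransferase EZH2 assay, hydrogen in place of hydroxy gives an at least 3.4-fold higher number from compound 3 to compound 4 (0.53 log units; beyond the scatter), and hydrogen in place of chloro gives an at least 20-fold higher number from compound 2 to compound 4 (1.31 log units; beyond the scatter), so chloro and hydroxy on this aromatic carbon each hold activity that hydrogen does not. In a physicochemical assay for lipophilicity, at pH 7.4 (on this read-out lower numbers stand for lower lipophilicity and higher numbers for higher lipophilicity), compound 3 gives 1.9 and compound 4 gives 1.7. In the physicochemical assay, the hydroxy to hydrogen change gives a number 0.20 log units lower from compound 3 to compound 4 (within the scatter), so the loss in the histone-lysine N-methyltransferase EZH2 assay comes without a readable shift on that read-out. Fluoro goes against any general gain from a substituent here, and its step to hydrogen cannot be read, since compound 1 and compound 4 sit at one limit: the limit of > 150000 nM in the histone-lysine N-methyltransferase EZH2 assay, at which 2 of the 4 values shown sit.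

On these data alone, whether bromo, methyl or an amine on this carbon would match or pass chloro stays open.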